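The compounds below may be only part of what the source reports. "The series", "measured", "known", "first", "only" and "open" are said of these compounds alone.

Measured so far:
- Compound 1 `COc1cc(OC)c(/C=C(\C(=O)c2ccc(Cl)cc2)S(=O)(=O)c2ccc(Br)cc2)c(OC)c1`: > 100000 nM (a limit)
- Compound 2 `COc1cc(OC)c(/C=C(/SCc2ccc(F)cc2)C(=O)c2ccc(Br)cc2)c(OC)c1`: 1000 nM

Within the data shown here, in a functional assay on DU-145 cells (Homo sapiens) for inhibition, read by trypan blue exclusion, with a stated time of 96 h (a lower number here means a stronger inhibitor of growth, a higher number a weaker inhibitor of growth), compound 2 gives 1000 nM, the only actual number so far. The entry for compound 1, > 100000 nM, is a limit of the assay and not a number. Among the measured compounds shown here, compounds 1 and 2 differ in more than one place, so no measured pair yet shows what a single swap does.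

Compound 3 `COc1cc(OC)c(/C=C(/SCc2ccc(F)cc2)C(=O)c2ccc(Cl)cc2)c(OC)c1` keeps the structure of compound 2 but has chloro in place of bromo on an aromatic carbon, para to a large group (chloro in place of bromo on an aromatic carbon). This turns the 4-bromophenyl into a 4-chlorophenyl and changes nothing else.

With compound 2 at 1000 nM as the only anchor, the expected step of no change at the digits printed from compound 2 to compound 3 (within the scatter) stays within the usual scatter, in neither direction. For compound 3, the estimated value is 1000 nM, with an expected range of 350 nM to 3000 nM.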

Compound 3, concentration for 50% growth inhibition: 10000 nM
For compound 3 the middle estimate is 10-fold (1.00 log units) below the measured one; the whole stated range lies below it.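

In this assay, changing one atom at this position, chloro in place of bromo on the aromatic carbon, gives a 10-fold higher number from compound 2 to compound 3 (1.00 log units; beyond the scatter), so this position is sensitive to which halogen it carries. Compound 3 also gives the first view of a single change at the other end of the molecule: (4-fluorobenzyl)sulfanyl in place of (4-bromophenyl)sulfonyl gives an at least 10-fold lower number from compound 1 to compound 3 (1.00 log units; beyond the scatter). That step gives only a minimum size, since compound 1 stands at a limit of the assay and not at a number: the limit of > 100000 nM in this assay, at which 1 of the 3 values shown sits.

A single pair of halogens cannot show what lies behind the step from bromo to chloro, so its cause stays open. As far as these compounds go, how a methoxy group, a nitrile or a plain hydrogen at the same position would read in this assay also stays open.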